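Moving the Chlorine Along the Chlorobenzylsulfanyl Arm

The source may report more compounds than this note shows. Statements on the series, on what has been measured and on what is new or still open speak of the compounds shown alone.

Of the compounds shown here, two sharing one core have been measured in a functional assay on the whole organism (artery, strain albino) with Rattus norvegicus as the target, with a stated time of 720 min, at a dose of 10 mg/kg by the oral route; a lower number here means less inhibition, a higher number more inhibition at the dose given (going by the name of the read-out). Compound 1, `CC1=C(C(=O)Nc2ccc(Br)cc2)C(c2ccc(Cl)cc2Cl)N=C(SCc2ccccc2)N1`, bears a benzylsulfanyl group; in this assay compound 1 gives 11.3%. Compound 2, `CC1=C(C(=O)Nc2ccc(Br)cc2)C(c2ccc(Cl)cc2Cl)N=C(SCc2cccc(Cl)c2)N1`, carries a (3-chlorobenzyl)sulfanyl group in its place, and in this assay compound 2 gives 11.3%. Going by the values given here, the only step among the measured pair, no change at the digits printed from compound 1 to compound 2 (within the scatter), shows that adding a chlorine to that aromatic ring left the read-out where it was.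

Compound 3, `CC1=C(C(=O)Nc2ccc(Br)cc2)C(c2ccc(Cl)cc2Cl)N=C(SCc2ccc(Cl)cc2)N1`, differs from compound 2 by 4-chlorophenyl in place of 3-chlorophenyl on a saturated chain carbon bound to a sulfur. Among the compounds with values here, no measured step moves the chlorine from one position of that ring to another, so the expectation rests on the single step available: introducing the chlorine in the first place changed nothing within the scatter, and a shift of the same atom on the same ring is not expected to do more. The estimated step is a number 0.3 percentage points lower from compound 2 to compound 3 (within the scatter), meaning none beyond the scatter. Compound 3 is therefore expected to give 11% in this assay, with a range from 0% to 25%.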

Compound 3, a percentage reported as inhibition, in the whole organism at one dose (the size of the read-out at that dose, not a potency): 25.8%
Compound 3: middle estimate off by 14.8 percentage points, on the low side, outside the stated range (above it).
By their numbers in this assay, from the lowest: compounds 1 and 2 (each within the scatter of the next); then compound 3.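

In this assay the place of the chlorine on the benzyl ring matters: 4-chlorophenyl in place of 3-chlorophenyl on a saturated chain carbon bound to a sulfur gives a number 14.5 percentage points higher from compound 2 to compound 3 (beyond the scatter) even though the two groups hold the same atoms. Set against the plain benzylsulfanyl group, the (4-chlorobenzyl)sulfanyl group gives a number 14.5 percentage points higher from compound 1 to compound 3 (beyond the scatter) while the (3-chlorobenzyl)sulfanyl group gave no change at the digits printed from compound 1 to compound 2 (within the scatter) and thus the silent first step held only for that one placing of the chlorine, not for chlorine on this ring as such. Nothing at hand accounts for why the two placings part in this way.

On these data alone, whether the rise belongs to chlorine itself remains open, since a methoxy group, a bromine or a carboxylic acid in its place on the 4-substituted ring could give a quite different number. As far as these compounds go, these three compounds also share the same bromoanilide amide and dichlorophenyl group and were read at one oral dose and one time, so it remains open whether the gap between the two chlorine placings would survive a change to either group or to that dose.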